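Swapping the aryl group on the shared core of compound 1

The source may hold more compounds than are shown below. What is called first, only, known or untested is meant among the compounds shown, and "the series" means these compounds.

Measured compounds:
- compound 1, `CC(c1ccc(-c2ccccc2)c(F)c1)c1nnc2n1N=C(c1ccc(Cl)cc1Cl)CS2`: 6600 nM
- compound 2, `CC(C)Cc1ccc(C(C)c2nnc3n2N=C(c2ccc(OC(F)(F)F)cc2)CS3)cc1`: 9100 nM

Both compounds were tested in a functional assay on Mahlavu cells (Homo sapiens) for inhibition, read by sulforhodamine B assay, with a stated time of 72 h; on this read-out higher numbers stand for weaker inhibition and lower numbers for stronger inhibition. Compound 1 gives 6600 nM and compound 2 gives 9100 nM; these two numbers lie within the usual scatter of each other, so compound 1 cannot be set apart from compound 2 on these data.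

The next compound, compound 3 (`CC(c1ccc(-c2ccccc2)c(F)c1)c1nnc2n1N=C(c1ccc(F)cc1)CS2`), has not yet been measured. It differs from compound 1 in one place: 4-fluorophenyl in place of 2,4-dichlorophenyl on a carbon with a double bond to nitrogen. For the measured compounds named here, no measured pair shows what such a swap does on this core, so there is nothing to lean on but the two numbers above.

Going by the values given here, with no comparable step available, a modest weakening is expected, and the step of a 1.4-fold higher number from compound 1 to compound 3 (0.13 log units; within the scatter) is estimated to stay near the scatter. Compound 3 is therefore expected to give about 9000 nM, with a range from 3500 nM to 25000 nM.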

Compound 3, half-maximal inhibitory concentration: 7400 nM
Estimate against measurement, compound 3: 1.2-fold (0.09 log units) above; measured number inside the range.
By their numbers in this assay, from the lowest: compounds 1, 3 and 2 (each within the scatter of the next).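

In this assay, putting 4-fluorophenyl in place of 2,4-dichlorophenyl on the carbon with a double bond to nitrogen gives a 1.1-fold higher number from compound 1 to compound 3 (0.05 log units; within the scatter). For the compounds shown here, this is the first pair here that differs in one place, and it shows that these two aryl groups cannot be told apart at this position on the shared core, even though one carries two chlorine atoms and the other a single fluorine. The data at hand offer no explanation for this result.

Going by these compounds, both groups are six-membered aromatic rings of carbon, so it remains open whether something of another kind at this position, such as a carboxylic acid, an amine or a short alkyl chain, would shift the number beyond the scatter. On these data alone, what a change elsewhere on the shared core would do also remains open.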